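Aryl ketone swap: from dimethoxyphenyl to difluorophenyl

The compounds below may be only part of what the source reports. "The series", "measured", "known", "first", "only" and "open" are said of these compounds alone.

Measured in a functional assay on COLO 205 cells (Homo sapiens) for inhibition, read by sulforhodamine B assay, with a stated time of 48 h; a lower number here means that less compound is tolerated, a higher number that more compound is tolerated:
- compound 1 `COc1cc(-c2cc(/C=C/C(=O)c3ccc(N)cc3)[nH]n2)cc(OC)c1OC`: 6420 nM
- compound 2 `COc1cc(-c2cc(/C=C/C(=O)c3ccc(Cl)c(Cl)c3)[nH]n2)cc(OC)c1OC`: > 100000 nM, a limit of the assay
- compound 3 `COc1ccc(C(=O)/C=C/c2cc(-c3cc(OC)c(OC)c(OC)c3)n[nH]2)cc1OC`: 5920 nM

Compound 3 stands level with compound 1, as the step of a 1.1-fold lower number from compound 1 to compound 3 (0.04 log units; within the scatter) shows. Both carry a number, while compound 2 reaches only a limit.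

The next compound is compound 4 `COc1cc(-c2cc(/C=C/C(=O)c3ccc(F)c(F)c3)[nH]n2)cc(OC)c1OC`. Its change is 3,4-difluorophenyl in place of 3,4-dimethoxyphenyl on a carbonyl carbon.

All three measured steps alter this same group. The step of a 1.1-fold lower number from compound 1 to compound 3 (0.04 log units; within the scatter) exchanges 4-aminophenyl for 3,4-dimethoxyphenyl and stays within the scatter, so this place does not always respond. The other two are large: an at least 15-fold higher number from compound 1 to compound 2 (1.19 log units; beyond the scatter) and an at least 16-fold lower number from compound 2 to compound 3 (1.22 log units; beyond the scatter). Both involve 3,4-dichlorophenyl, the measured group that most resembles the incoming one, and the latter step removes it in favour of the group compound 4 gives up. Going by the values given here, only one such compound has been measured, so this reading rests on compound 2 alone.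

A move towards more tolerated compound is therefore expected in this assay, probably beyond the scatter but smaller than the steps involving compound 2. The expected change is a 4.2-fold higher number from compound 3 to compound 4 (0.63 log units; beyond the scatter). The estimate for compound 4 is 25000 nM, with an expected range from 6000 nM to 100000 nM.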

Compound 4, concentration lethal to 50% of the cells: 6000 nM
Compound 4: middle estimate off by 4.2-fold (0.62 log units), on the high side, and the stated range covers the measured number.
By their numbers in this assay, from the lowest: compounds 3, 4 and 1 (each within the scatter of the next). At a limit, above all of these: compound 2.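

In this assay, 3,4-difluorophenyl on a carbonyl carbon shows no separation from 3,4-dimethoxyphenyl, a 1.0-fold higher number from compound 3 to compound 4 (0.01 log units; within the scatter), or from 4-aminophenyl, a 1.1-fold lower number from compound 1 to compound 4 (0.03 log units; within the scatter), so three different groups now share one level at this place, and the 2 hydrogen-bond acceptors of 3,4-dimethoxyphenyl are not needed to hold that level. The two halogen-bearing groups part sharply, an at least 16-fold lower number from compound 2 to compound 4 (1.22 log units; beyond the scatter), so among the compounds shown the outlying result is tied to 3,4-dichlorophenyl and not to halogen on the aryl ketone as such. Compound 2 gives a limit and not a number, so the full size of that step stays unknown: the limit of > 100000 nM in this assay, at which 1 of the 4 values shown sits.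

Still open, from the compounds shown here alone, is whether 4-chlorophenyl or 3-chlorophenyl would stay level with compound 4 or go the way of compound 2, which would trace the outlying result to one of the two chlorines or to the pair. Also open, going by these compounds, is whether a more distant group at this place, such as a carboxylic acid, a morpholine or a pyridine ring, would leave the shared level intact.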